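Amine tail exchange and tolerated concentration in liver cells

The source may hold more compounds than are shown below. What is called first, only, known or untested is meant among the compounds shown, and "the series" means these compounds.

Measured so far:
compound 1, `Cc1ccccc1-c1nn(-c2ccc(F)cc2F)cc1CNCCN(C)C`, > 20000 nM
compound 2, `CCCN1CCC(CNCc2cn(-c3ccc([N+](=O)[O-])cc3)nc2-c2ccc(OC(F)(F)F)cc2)CC1`, 18000 nM

Of the compounds shown here, two have been tested in an ADME assay on Huh-7 cells (Homo sapiens) for cytotoxicity; a higher number here means that more compound is tolerated, a lower number that less compound is tolerated. For compound 1 the reported value of > 20000 nM is a limit of the assay and not a number; it stands at the limit of > 20000 nM in this assay, at which 1 of the 2 values shown sits. Compound 2 gives 18000 nM in this assay, a number rather than a limit. The two compounds share no single-point change, so their values are simply two readings from the same assay and nothing more is drawn from the pair.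

Compound 3, `Cc1ccccc1-c1nn(-c2ccc(F)cc2F)cc1CNCCCN1CCN(C)CC1`, has not yet been measured. It differs from compound 1 in one place: (4-methylpiperazin-1-yl)methyl in place of dimethylamino on a saturated chain carbon, two bonds along the chain from an amine nitrogen. Among the compounds with values here, no measured pair shows what this exchange does in this assay, so the size of the step is open. The expected step of a number no higher from compound 1 to compound 3 (the limit leaves the size open) is none beyond the usual scatter, since compound 1 already sits at the limit of the assay. Compound 3 is therefore estimated at 20000 nM, with a range from 8000 nM to 40000 nM.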

Compound 3, half-maximal cytotoxic concentration: > 20000 nM
Compound 3 gave a limit, no number; the forecaster's own chance of this, stated with the estimate: 60%; the middle value lies on the limit itself.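

In this assay compound 3 gives > 20000 nM, which is a limit and not a number. No step can be read between compound 1 and compound 3, because both sit at the same limit: the limit of > 20000 nM in this assay, at which 2 of the 3 values shown sit.

The compounds shown leave open what the exchange of dimethylamino for (4-methylpiperazin-1-yl)methyl does in this assay.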